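This account rests on a few compounds, and the source may have more. Where it says the series, first, only, none or still open, it means among the compounds named here.

Measured in a functional assay on HepG2 cells (Homo sapiens) for inhibition, read by MTT assay, with a stated time of 24 h; a higher number here means a weaker inhibitor of growth, a lower number a stronger inhibitor of growth:

- Compound 1 `Cn1cc(-c2nc3ccccc3n2C(=O)c2ccccc2)c2cc(Br)ccc21`: 48100 nM
- Compound 2 `COc1ccccc1C(=O)n1c(-c2cn(C)c3ccc(Br)cc23)nc2ccccc21`: 34600 nM
- Compound 3 `COc1ccc(C(=O)n2c(-c3cn(C)c4ccc(Br)cc34)nc3ccccc32)cc1`: 18900 nM

Compound 3 stands at the low end of this small set. Its gap to the nearest neighbour is small, a 1.8-fold lower number from compound 2 to compound 3 (0.26 log units; within the scatter), and its gap to the furthest is modest, a 2.5-fold lower number from compound 1 to compound 3 (0.41 log units; beyond the scatter). The next compound, compound 4 `Cn1cc(-c2nc3ccccc3n2C(=O)c2ccccc2Br)c2cc(Br)ccc21`, carries 2-bromophenyl in place of 4-methoxyphenyl on a carbonyl carbon. Among the measured compounds shown here, no measured step tests a bromine on this phenyl ring. The closest guide is the 2-methoxyphenyl group of compound 2, whose step from the unsubstituted compound was slight, a 1.4-fold lower number from compound 1 to compound 2 (0.14 log units; within the scatter). A small move towards a higher number is therefore expected, with the expected step being a 1.6-fold higher number from compound 3 to compound 4 (0.20 log units; within the scatter). Compound 4 is estimated at 30000 nM, with an expected range of 14000 nM to 60000 nM.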

Compound 4, concentration for 50% growth inhibition: 72100 nM
Compound 4: the middle estimate sits 2.4-fold (0.38 log units) below what was measured; the whole stated range lies below it.
By their numbers in this assay, from the lowest: compounds 3, 2, 1 and 4 (each within the scatter of the next, the first and the last beyond it).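

On the carbonyl carbon, 2-bromophenyl cannot be told apart from the unsubstituted phenyl (a 1.5-fold higher number from compound 1 to compound 4 (0.18 log units; within the scatter)). Among the compounds shown here, the choice between bromo and methoxy does register, however, both against 2-methoxyphenyl (a 2.1-fold higher number from compound 2 to compound 4 (0.32 log units; beyond the scatter)) and against 4-methoxyphenyl (a 3.8-fold higher number from compound 3 to compound 4 (0.58 log units; beyond the scatter)), so a substituent on this ring can separate compounds by more than the earlier steps alone showed. No evidence at hand explains this difference. As far as these compounds go, whether an amine or a carboxylic acid on this phenyl ring would move the number stays open. So does whether chloro or fluoro would behave like bromo.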